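Trifluoromethyl on the Phenyl of a Nitrobenzofurazan Ester Amide

The source may hold more compounds than are shown below. What is called first, only, known or untested is meant among the compounds shown, and "the series" means these compounds.

Compound 1 `O=C(CCC(=O)OCCCCCCSc1ccc([N+](=O)[O-])c2nonc12)Nc1ccccc1` was tested in a functional assay on HOS cells (Homo sapiens) for inhibition, read by MTT assay, with a stated time of 72 h (on this read-out higher numbers stand for weaker inhibition and lower numbers for stronger inhibition), and gave 2120 nM. Among the three compounds measured, compound 1 holds the second highest number: compound 2 `O=C(CCC(=O)OCCCCCCSc1ccc([N+](=O)[O-])c2nonc12)Nc1ccccc1F` sits nearest with 2350 nM, and compound 3 `COc1ccc(NC(=O)CCC(=O)OCCCCCCSc2ccc([N+](=O)[O-])c3nonc23)cc1` furthest with 1800 nM. Both neighbours carry a single change on the phenyl group, and neither change moved the read-out beyond the scatter: a 1.1-fold higher number from compound 1 to compound 2 (0.04 log units; within the scatter), and a 1.2-fold lower number from compound 1 to compound 3 (0.07 log units; within the scatter); between them, a 1.3-fold lower number from compound 2 to compound 3 (0.12 log units; within the scatter).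

Compound 4 `O=C(CCC(=O)OCCCCCCSc1ccc([N+](=O)[O-])c2nonc12)Nc1ccc(C(F)(F)F)cc1` has not yet been measured. It differs from compound 1 in this way: trifluoromethyl in place of hydrogen on an aromatic carbon

Going by the values given here, the steps that bear on this change are the two substitutions on the phenyl group already seen, from compound 1 to compound 2 and from compound 1 to compound 3, both within the scatter. The author therefore expects no step beyond the scatter in this assay, estimating a 1.0-fold lower number from compound 1 to compound 4 (0.00 log units; within the scatter). Compound 4 is expected to give 2100 nM, with a range from 1000 nM to 4500 nM.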

Compound 4, half-maximal inhibitory concentration: 3200 nM
The estimate for compound 4 lay 1.5-fold (0.18 log units) below the measured number; the measured number falls inside the stated range.
By their numbers in this assay, from the lowest: compounds 3, 1, 2 and 4 (each within the scatter of the next).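

In this assay the phenyl group of the shared core also accepts trifluoromethyl without any step beyond the scatter, as 4-(trifluoromethyl)phenyl stays within the scatter of all three earlier compounds (a 1.5-fold higher number from compound 1 to compound 4 (0.18 log units; within the scatter); a 1.4-fold higher number from compound 2 to compound 4 (0.13 log units; within the scatter); a 1.8-fold higher number from compound 3 to compound 4 (0.25 log units; within the scatter)). Even the exchange of methoxy for trifluoromethyl, the largest of the steps so far, does not leave the scatter, so fluoro, methoxy and trifluoromethyl on this phenyl group cannot be told apart on this read-out. No measurement is available that would account for these numbers.

The compounds shown leave open whether an amine or a carboxylic acid on the phenyl group would produce a step beyond the scatter. They also leave open whether a longer chain between the ester and the core would do so.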